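This account rests on a few compounds, and the source may have more. Where it says the series, first, only, none or still open, it means among the compounds named here.

Measured compounds, all in a toxicity assay on THP-1 cells (Homo sapiens) for inhibition; a lower number here means that less compound is tolerated, a higher number that more compound is tolerated:
- compound 1, `Cc1cccc(C(=O)Nc2ncc(-c3ccccc3)n2C)c1`: > 50000 nM, a limit of the assay rather than a number
- compound 2, `COc1ccc(-c2cnc(NC(=O)c3cccc(Cl)c3)n2C)cc1`: > 28000 nM, again a limit
- compound 3, `COc1ccc(-c2cnc(NC(=O)c3cccc(C)c3)n2C)cc1`: > 100000 nM, again a limit

Compound 1 therefore stands only at a limit, as do the other two. Its own place is the limit of > 50000 nM in this assay, at which 1 of the 3 values shown sits. Compound 3 sits at the limit of > 100000 nM in this assay, at which 1 of the 3 values shown sits. Compound 2 sits at the limit of > 28000 nM in this assay, at which 1 of the 3 values shown sits. Every value is a limit. The two measured steps, a step that the two limits leave unreadable from compound 1 to compound 3 and a step that the two limits leave unreadable from compound 2 to compound 3, cannot be read for size or direction.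

Compound 4, `Cn1c(-c2ccccc2)cnc1NC(=O)c1ncc[nH]1`, differs from compound 1 in one place: 1H-imidazol-2-yl in place of 3-methylphenyl on a carbonyl carbon. Neither measured step touches this kind of change, and neither gives a readable size, so no step beyond the scatter can be expected in either direction; the most likely outcome is once more a limit. The step from compound 1 to compound 4 is estimated as a step that the limit leaves unreadable from compound 1 to compound 4. Compound 4 is expected to give 60000 nM, with a range from 20000 nM to 200000 nM.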

Compound 4, half-maximal cytotoxic concentration: > 100000 nM
Compound 4 was reported as a limit; the forecaster's own chance of this, stated with the estimate: 85%; at least 1.6-fold (0.22 log units) between middle value and limit.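

Compound 1 and compound 4 are both reported only as limits of the assay, not as numbers, so the size and direction of the change between them cannot be read. The compounds shown leave open at what concentration any of them becomes toxic in this assay, and whether 1H-imidazol-2-yl in place of 3-methylphenyl changes that concentration at all.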